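A few compounds are considered here, and "the series" means these few. Any claim that something is new, unique, unknown or untested is made for them only; others in the source may bear on it.

Measured so far in an ADME assay on Vero cells (Chlorocebus sabaeus) for cytotoxicity, read by MTT assay, with a stated time of 48 h; a lower number here means that less compound is tolerated, a higher number that more compound is tolerated:
Compound 1 `C=C1CC[C@H]2[C@@](C)(CCC(=O)[C@@]2(C)COC(C)=O)[C@@H]1C/C=C1/C(=O)OC[C@@H]1Oc1cccc2ccc(C)nc12` gives 46700 nM.
Compound 2 `C=C1CC[C@@H]2[C@](C)(CO)[C@H](O)CC[C@@]2(C)[C@@H]1C/C=C1/C(=O)OC[C@H]1Oc1ccnc2ccccc12` gives 22800 nM.
Compound 3 `C=C1CC[C@H]2[C@@](C)(CCC(=O)[C@@]2(C)COC(C)=O)[C@@H]1C/C=C1/C(=O)OC[C@@H]1Oc1c(Cl)cc(Cl)c2cccnc12` gives 57400 nM.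

On these three numbers compound 1 stands second highest. Going by the values given here, its nearest neighbour is compound 3, reached by the single measured step, a 1.2-fold higher number from compound 1 to compound 3 (0.09 log units; within the scatter), which swaps one aryl group on an oxygen on a saturated carbon for another and stays within the scatter. Its furthest neighbour is compound 2, whose value of 22800 nM lies beyond the scatter from compound 1; the two differ in many places at once, so no single step can be read from that pair.

Compound 4 `C=C1CC[C@H]2[C@@](C)(CCC(=O)[C@@]2(C)COC(C)=O)[C@@H]1C/C=C1/C(=O)OC[C@H]1Oc1cccc2ccc(C)nc12` is the subject here. (the two compounds have the same atoms and bonds and differ only in configuration as drawn: 1 of 6 stereo elements differ; a stereocentre at a saturated ring carbon is drawn R in compound 1 and S in compound 4). Among the compounds with values here, no measured step concerns a change of configuration alone: the only step available, a 1.2-fold higher number from compound 1 to compound 3 (0.09 log units; within the scatter), is of a different kind and was itself within the scatter. With nothing pointing in either direction, the expected step in this assay is no change at the digits printed from compound 1 to compound 4 (within the scatter), that is, none beyond the scatter. Compound 4 is therefore estimated at 46700 nM, with a range from 23000 nM to 95000 nM.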

Compound 4, half-maximal cytotoxic concentration: 72400 nM
For compound 4 the middle estimate is 1.6-fold (0.19 log units) below the measured one; the range from low to high includes it.
By their numbers in this assay, from the lowest: compound 2; then compounds 1, 3 and 4 (each within the scatter of the next).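

In this assay, a change of configuration alone, at a saturated ring carbon, gives a 1.6-fold higher number from compound 1 to compound 4 (0.19 log units; within the scatter). Going by these compounds alone, the earlier step concerned only an exchange of the aryl group on the oxygen, so this pair is the first evidence on the stereocentre itself: here, going from R to S produces no shift beyond the scatter. The comparison isolates that one stereo element, with the other five drawn alike and no group entering or leaving: the fact that compounds 1 and 4 differ only in the configuration as drawn.

As far as these compounds go, it remains open whether the same change at this carbon would also stay within the scatter with 5,7-dichloroquinolin-8-yl on the oxygen instead of 2-methylquinolin-8-yl. Also open, from the compounds shown here alone, is how this assay would respond to a simple amine or a carboxylic acid in place of that aryl group, in either configuration.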